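Taking the ethoxy group off compound 3

The source may report more compounds than this note shows. Statements on the series, on what has been measured and on what is new or still open speak of the compounds shown alone.

In a functional assay on SW-620 cells (Homo sapiens) for cytotoxicity (a higher number here means a weaker inhibitor, a lower number a stronger inhibitor), compound 3 (`CCOc1ccc2nc(NC(=O)CCCCC(=O)NO)sc2c1`) gives 9.26 ug/mL, and compound 1 (`COc1ccc2nc(NC(=O)CCCCC(=O)NO)sc2c1`) gives 9.07 ug/mL, within the scatter of it. Compound 2 (`O=C(CCCCCCC(=O)Nc1nc2ccccc2s1)NO`) gives 4.01 ug/mL, a lower number than compound 3 by more than the scatter. Compound 4 (`O=C(CCCCC(=O)Nc1nc2ccccc2s1)NO`) carries hydrogen in place of ethoxy on an aromatic carbon. Going by the values given here, the one measured step at this place, a 1.0-fold higher number from compound 1 to compound 3 (0.01 log units; within the scatter), stayed within the scatter, though it did not remove the group. Compound 2 also lacks the group but differs from compound 4 in its chain as well. The expected change, a 1.2-fold lower number from compound 3 to compound 4 (0.06 log units; within the scatter), is therefore none beyond the scatter. For compound 4 the estimate is 8 ug/mL, with an expected range of 3.5 ug/mL to 17 ug/mL.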

Compound 4, half-maximal inhibitory concentration: 7.85 ug/mL
Beside the measured number, compound 4's estimate is 1.0-fold (0.01 log units) above it; the measured number falls inside the stated range.
By their numbers in this assay, from the lowest: compounds 2, 4, 1 and 3 (each within the scatter of the next, the first and the last beyond it).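

In this assay the step of a 1.2-fold lower number from compound 3 to compound 4 (0.07 log units; within the scatter) and the step of a 1.2-fold lower number from compound 1 to compound 4 (0.06 log units; within the scatter) show that taking the group away entirely, leaving hydrogen on this aromatic carbon, changes the number no more than swapping methoxy for ethoxy did. The chain change, a 2.0-fold higher number from compound 2 to compound 4 (0.29 log units; within the scatter) for hydroxycarbamoyl in place of 2-(hydroxycarbamoyl)ethyl, also stays within the scatter. Nothing available here offers a reason for these results.

On these data alone, whether an amine, a carboxylic acid or a chlorine atom on this aromatic carbon would move the number beyond the scatter remains open, as does the effect of a longer chain on the ethoxy compound.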